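Swapping phenyl for methylpyrazolyl on the amino nitrogen

The source may hold more compounds than are shown below. What is called first, only, known or untested is meant among the compounds shown, and "the series" means these compounds.

Measured compounds:
- compound 1, `CN(c1ccccc1)c1cnc(NCc2c(F)ccc3c2CCO3)n2cnnc12`: 3.6
- compound 2, `CN(C)Cc1ccc2c(c1)CN(c1cnc(NCc3c(F)ccc4c3CCO4)c3cn[nH]c(=O)c13)C2=O`: 2.2
- compound 3, `Cc1nc(CN(C)C)ccc1-c1cnc(NCc2c(F)ccc3c2CCO3)c2cn[nH]c(=O)c12`: 2

Of the compounds shown here, three have been measured in a physicochemical assay for lipophilicity, using the shake flask method, in phosphate buffer, measured as octanol-water partition, with a stated time of 30 min, at pH 7.4; on this read-out lower numbers stand for lower lipophilicity and higher numbers for higher lipophilicity. Compound 1 stands highest of the three; compound 2 lies well below it, and compound 3 lies lower still, both gaps beyond the usual scatter. Compounds 2 and 3 are built on a different core from compound 1, so their values show only where they sit, not how any single change moves the number.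

The compound that follows is compound 4, `CN(c1ccn(C)n1)c1cnc(NCc2c(F)ccc3c2CCO3)n2cnnc12`. It differs from compound 1 in one place: 1-methyl-1H-pyrazol-3-yl in place of phenyl on a nitrogen on an aromatic ring. For the measured compounds named here, no pair of measured compounds shows this kind of change, so the expectation must come from the change itself. A five-membered aromatic ring with two hetero atoms entering in place of a ring of carbon only is expected to lower the read-out. The step from compound 1 to compound 4 in this assay is expected to be a number 1.20 log units lower from compound 1 to compound 4 (beyond the scatter), downward and beyond the scatter. Compound 4 is therefore estimated at 2.4, within 1.8 to 3.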

Compound 4, distribution coefficient: 1.8
Compound 4: middle estimate off by 0.60 log units, on the high side, within the range that was stated.
By their numbers in this assay, from the lowest: compounds 4, 3 and 2 (each within the scatter of the next, the first and the last beyond it); then compound 1.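

On the core of compound 1, placing 1-methyl-1H-pyrazol-3-yl in place of phenyl on a nitrogen on an aromatic ring moves this assay by a number 1.80 log units lower from compound 1 to compound 4 (beyond the scatter) and counts as a large step, so this position responds strongly to the identity of the ring. Both groups have 6 heavy atoms and no net charge, so the step comes with no change in the number of heavy atoms; what differs is the ring itself, with 2 nitrogen atoms and 2 hydrogen-bond acceptors entering where phenyl has 0. Nothing measured here explains why the number falls this far.

This single pair cannot show whether the same swap would give a step of similar size on another core. As far as these compounds go, what a pyridyl group or a short amine chain would do in the same place also remains open.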